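A few compounds are considered here, and "the series" means these few. Any claim that something is new, unique, unknown or untested is made for them only; others in the source may bear on it.

In a functional assay on the whole organism for positive allosteric modulation, with Mus musculus as the target (a higher number here means that more compound is needed for the effect, a lower number that less compound is needed), compound 1 `CCC(=O)N(c1ccc(Cl)c(Cl)c1)C1CCCC1O` gives 0.4 mg/kg. Compound 2 `CCC(=O)N(c1ccc(Cl)c(Cl)c1)C1CCCC1N` gives 0.02 mg/kg, with amino in place of hydroxy on a saturated ring carbon, which is a 20-fold lower number from compound 1 to compound 2 (1.30 log units; beyond the scatter). Compound 3 `CCNC1CCCC1N(C(=O)CC)c1ccc(Cl)c(Cl)c1` gives 0.2 mg/kg. This value lies within the scatter of compound 1, as a 2.0-fold lower number from compound 1 to compound 3 (0.30 log units; within the scatter) shows, and clearly apart from compound 2, as a 10-fold higher number from compound 2 to compound 3 (1.00 log units; beyond the scatter) shows.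

Compound 4 `C=CCNC1CCCC1N(C(=O)CC)c1ccc(Cl)c(Cl)c1` has not yet been measured in this assay. Its change from compound 3 is vinyl in place of methyl on a saturated chain carbon bound to an amine nitrogen, or ethylamino to allylamino: vinyl in place of methyl on a saturated chain carbon bound to an amine nitrogen.

Among the compounds with values here, the closest evidence is a 10-fold higher number from compound 2 to compound 3 (1.00 log units; beyond the scatter), the only measured step that alters a substituent on this amine nitrogen. Within the data shown here, it adds an ethyl to a hydrogen, however, and no measured pair varies the chain itself. The steps away from hydroxy, a 20-fold lower number from compound 1 to compound 2 (1.30 log units; beyond the scatter) and a 2.0-fold lower number from compound 1 to compound 3 (0.30 log units; within the scatter), bear on the change only indirectly. A step within the scatter is therefore expected, leaning slightly toward a higher number because of a 10-fold higher number from compound 2 to compound 3 (1.00 log units; beyond the scatter). The estimated step is a 1.3-fold higher number from compound 3 to compound 4 (0.10 log units; within the scatter). Compound 4 is estimated at 0.25 mg/kg, with an expected range from 0.08 mg/kg to 0.8 mg/kg.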

Compound 4, dose for half-maximal effect: 0.2 mg/kg
Compound 4: the middle estimate sits 1.3-fold (0.10 log units) above what was measured; measured number inside the range.
By their numbers in this assay, from the lowest: compound 2; then compounds 3, 4 and 1 (each within the scatter of the next).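

In this assay, within the data shown here, the first measured step that alters the chain on this amine nitrogen, rather than adding one, is ethylamino to allylamino, and it leaves the number unchanged (no change at the digits printed from compound 3 to compound 4 (within the scatter)). The loss seen on substituting the free amine now holds for two groups, since allyl (a 10-fold higher number from compound 2 to compound 4 (1.00 log units; beyond the scatter)) gives a step of the same size as ethyl (a 10-fold higher number from compound 2 to compound 3 (1.00 log units; beyond the scatter)), while allylamino in place of hydroxy stays within the scatter (a 2.0-fold lower number from compound 1 to compound 4 (0.30 log units; within the scatter)), as ethylamino did. No measurement available here explains the flat step or the loss from the free amine.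

Only two substituents on this nitrogen are shown, so it remains open whether a smaller methyl keeps the low number of compound 2 (0.02 mg/kg) or whether the loss already appears with any added carbon. Also open, as far as these compounds go, is how far the chain can be varied without a step beyond the scatter, which a longer chain such as butyl, a branched isopropyl or a benzyl group on the same nitrogen would show.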